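A few compounds are considered here, and "the series" means these few. Any claim that something is new, unique, unknown or untested is made for them only; others in the source may bear on it.

Compound 1 `COCc1cc(CCCOc2c(C)cc(-c3noc(C(F)(F)F)n3)cc2C)on1` and compound 2 `CC(=O)c1ccc(CCCOc2c(C)cc(-c3noc(C(F)(F)F)n3)cc2C)o1` share one core and differ in a single place: 5-acetylfuran-2-yl in place of 3-(methoxymethyl)-1,2-oxazol-5-yl on a saturated chain carbon, three bonds along the chain from an oxygen on an aromatic ring. In an in vitro ADME assay on microsomes from liver (Simiiformes) (a lower number here means that the compound disappears faster, a higher number that the compound lasts longer), compound 1 gives 1.58 h, and compound 2 gives 1.05 h, so this change made a 1.5-fold lower number from compound 1 to compound 2 (0.18 log units; within the scatter). Compound 3 `COCc1cc(CCCOc2c(C)cc(-c3noc(C)n3)cc2C)on1` carries a different core; how it differs from compound 1 is methyl in place of trifluoromethyl on an aromatic carbon, a change that made a 3.2-fold lower number from compound 1 to compound 3 (0.50 log units; beyond the scatter). In this assay compound 3 gives 0.5 h, the lowest of the three numbers. Compound 4 `CC(=O)c1ccc(CCCOc2c(C)cc(-c3noc(C)n3)cc2C)o1` has not been measured yet and stands to compound 3 as compound 2 stands to compound 1: the change is 5-acetylfuran-2-yl in place of 3-(methoxymethyl)-1,2-oxazol-5-yl on a saturated chain carbon, three bonds along the chain from an oxygen on an aromatic ring, at the same place as before, so it is the same change carried onto the other core. Because the earlier step of a 1.5-fold lower number from compound 1 to compound 2 (0.18 log units; within the scatter) stayed within the scatter, the step from compound 3 to compound 4 is expected to be about as small, a 1.4-fold lower number from compound 3 to compound 4 (0.15 log units; within the scatter). The value expected for compound 4 in this assay is 0.35 h, most likely falling between 0.18 h and 0.7 h.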

Compound 4, half-life: 0.617 h
Estimate against measurement, compound 4: 1.8-fold (0.25 log units) below; the measured number falls inside the stated range.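

Placing 5-acetylfuran-2-yl where 3-(methoxymethyl)-1,2-oxazol-5-yl stood stays small on the second core too, with a 1.2-fold higher number from compound 3 to compound 4 (0.09 log units; within the scatter), and the two steps in this assay agree as far as the scatter allows: the same change on two cores in this assay, a 1.5-fold lower number (0.18 log units; within the scatter) from compound 1 to compound 2 and a 1.2-fold higher number (0.09 log units; within the scatter) from compound 3 to compound 4, 1.9-fold (0.27 log units) apart, within the scatter of two such steps. The methyl in place of trifluoromethyl gives a 1.7-fold lower number from compound 2 to compound 4 (0.23 log units; within the scatter), which lies within the scatter although its counterpart on the other core lies beyond it, yet the gap between these two steps is still no larger than repeated measurements could produce: the same change on two cores in this assay, a 3.2-fold lower number (0.50 log units; beyond the scatter) from compound 1 to compound 3 and a 1.7-fold lower number (0.23 log units; within the scatter) from compound 2 to compound 4, 1.9-fold (0.27 log units) apart, within the scatter of two such steps. So in these four compounds, each change carries from one core to the other without a detectable difference, but this rests on just one pair of steps per change and does not show that the steps are identical or that they would hold on any further core.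

On these data alone, it remains open whether the same agreement would hold for a longer chain or for an amine in place of the five-membered ring at the chain end. Also open, as far as these compounds go, is how an ethyl or a cyclopropyl group would compare with methyl and trifluoromethyl.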